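From a Free Acid to a Fluorinated Anilide

The compounds below may be only part of what the source reports. "The series", "measured", "known", "first", "only" and "open" are said of these compounds alone.

The series shares one core, carried by compound 1 `O=C(O)CCC(=O)OCCCCCCSc1ccc([N+](=O)[O-])c2nonc12`, compound 2 `O=C(CCC(=O)OCCCCCCSc1ccc([N+](=O)[O-])c2nonc12)Nc1ccccc1F`, compound 3 `Cc1ccccc1NC(=O)CCC(=O)OCCCCCCSc1ccc([N+](=O)[O-])c2nonc12` and the still unmeasured compound 4 `O=C(CCC(=O)OCCCCCCSc1ccc([N+](=O)[O-])c2nonc12)Nc1ccc(F)cc1`. Within the data shown here, in a functional assay on HOS cells (Homo sapiens) for inhibition, read by MTT assay, with a stated time of 72 h (on this read-out higher numbers stand for weaker inhibition and lower numbers for stronger inhibition), compound 1 gives 8740 nM, the highest of the three numbers measured so far; compound 2 gives 2350 nM and compound 3 gives 4020 nM. Replacing hydroxy on a carbonyl carbon lowers the number in both measured cases: a 3.7-fold lower number from compound 1 to compound 2 (0.57 log units; beyond the scatter) and a 2.2-fold lower number from compound 1 to compound 3 (0.34 log units; beyond the scatter), whereas a 1.7-fold higher number from compound 2 to compound 3 (0.23 log units; within the scatter).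

Compound 4 differs from compound 1 in one place: (4-fluorophenyl)amino in place of hydroxy on a carbonyl carbon. The steps from compound 1 to compound 2 and from compound 1 to compound 3 bear directly on it, since each puts (2-fluorophenyl)amino or (2-methylphenyl)amino in place of hydroxy on a carbonyl carbon and each gave a modest lowering. A downward step of similar size is therefore expected in this assay for compound 4. Compound 4 is expected to give 2800 nM, between 1200 nM and 6500 nM, which would correspond to a 3.1-fold lower number from compound 1 to compound 4 (0.49 log units; beyond the scatter).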

Compound 4, half-maximal inhibitory concentration: 2080 nM
Compound 4: middle estimate off by 1.3-fold (0.13 log units), on the high side; the range from low to high includes it.
By their numbers in this assay, from the lowest: compounds 4, 2 and 3 (each within the scatter of the next); then compound 1.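

In this assay, (4-fluorophenyl)amino on the carbonyl carbon also lowers the number relative to hydroxy (a 4.2-fold lower number from compound 1 to compound 4 (0.62 log units; beyond the scatter)), so a third aromatic amino group at this place gives a step beyond the scatter. The three amides cannot be told apart: 4-fluorophenyl in place of 2-fluorophenyl on the amide-type nitrogen changes nothing that can be read (a 1.1-fold lower number from compound 2 to compound 4 (0.05 log units; within the scatter)), and 4-fluorophenyl in place of 2-methylphenyl also stays within the scatter (a 1.9-fold lower number from compound 3 to compound 4 (0.29 log units; within the scatter)). Nothing measured on these compounds speaks to what lies behind these steps.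

The compounds shown leave open whether the fluoro or methyl group matters at all, which an unsubstituted phenylamino group would test. They also leave open whether a saturated amine such as morpholine or a simple methyl ester at the same carbonyl carbon would give a similar step.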